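This account rests on a few compounds, and the source may have more. Where it says the series, first, only, none or still open, it means among the compounds named here.

Two compounds share the same core, and in both the group attached to the amide carbonyl is varied. Compound 1 `Cc1nc(C(=O)Nc2ccc(Cl)c(-c3nnc4c(Cl)cccn34)c2)cs1` carries a 2-methyl-1,3-thiazol-4-yl group on the carbonyl carbon. In a functional assay on AN3-CA cells (Homo sapiens) for antiproliferative activity, read by MTT assay, with a stated time of 72 h (a higher number here means a weaker inhibitor, a lower number a stronger inhibitor), compound 1 gives only a limit, > 100000 nM, so no number is known for it. Compound 2 `O=C(Nc1ccc(Cl)c(-c2nnc3c(Cl)cccn23)c1)c1ccc(C(F)(F)F)cc1F` carries a substituted phenyl ring on the same carbonyl, and in this assay compound 2 gives 41200 nM, a number rather than a limit. Compound 3 `Cc1cc(Cl)ccc1C(=O)Nc1ccc(Cl)c(-c2nnc3c(Cl)cccn23)c1` has not yet been measured; it differs from compound 1 in one place: 4-chloro-2-methylphenyl in place of 2-methyl-1,3-thiazol-4-yl on a carbonyl carbon. Among the compounds with values here, no step between measured compounds is available, so the size of this change has to be expected rather than read off. Compound 2 also carries a phenyl ring on the carbonyl and gives 41200 nM, which makes a move toward stronger inhibition plausible, though its size is uncertain. The expected step is an at least 3.3-fold lower number from compound 1 to compound 3 (0.52 log units; beyond the scatter). Compound 3 is expected to give 30000 nM, between 8000 nM and 100000 nM.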

Compound 3, half-maximal inhibitory concentration: > 100000 nM
Compound 3 gave a limit, no number; the forecaster's own chance of this, stated with the estimate: 30%; at least 3.3-fold (0.52 log units) between middle value and limit.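

Within the data shown here, compound 1 and compound 3 each give a limit rather than a number, so no step between them can be read, because both values stop at the same edge of the measurement: the limit of > 100000 nM in this assay, at which 2 of the 3 values shown sit.
The compounds shown leave open how far either lies past that limit, and whether 4-chloro-2-methylphenyl in place of 2-methyl-1,3-thiazol-4-yl changes the result in this assay at all.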